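A few compounds are considered here, and "the series" means these few. Any claim that something is new, unique, unknown or untested is made for them only; others in the source may bear on it.

In an ADME assay on MT4 cells (Homo sapiens) for cytotoxicity, read by MTT assay, with a stated time of 96 h (a higher number here means that more compound is tolerated, a lower number that less compound is tolerated), compound 3 `FC(F)(F)c1ccc(NCc2cn(-c3ccccc3)nc2-c2ccc(C(F)(F)F)cc2)cc1` stands only at a limit, > 100000 nM. Compound 1 `Cc1ccc(NCc2cn(-c3ccccc3)nc2-c2ccc(C(F)(F)F)cc2)cc1` is also reported as a limit, > 100000 nM. Compound 2 `FC(F)(F)c1ccc(NCc2cn(-c3ccccc3)nc2-c2ccc(Br)cc2)cc1` is likewise a limit, > 100000 nM. The change to compound 4 `FC(F)(F)c1ccc(NCc2cn(-c3ccccc3)nc2-c2ccc(Cl)cc2)cc1` is chloro in place of trifluoromethyl on an aromatic carbon. The measured steps that bear on it are a step that the two limits leave unreadable from compound 1 to compound 3 and a step that the two limits leave unreadable from compound 2 to compound 3, so neither gives a size to carry over. Compound 3 sits with the others at the limit of > 100000 nM in this assay, at which 3 of the 3 values shown sit, so no step beyond the scatter is expected in this assay, and another limit is the likely report. The expected step is a number no higher from compound 3 to compound 4 (the limit leaves the size open). The estimate for compound 4 is 100000 nM, with an expected range of 50000 nM to 200000 nM.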

Compound 4, half-maximal cytotoxic concentration: > 100000 nM
Compound 4: no number, only a limit; the forecaster's own chance of this, stated with the estimate: 85%; the middle value sits exactly at the limit.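

In this assay, among these compounds, compound 2, compound 3 and compound 4 all stand as limits, so no step to compound 4 can be read. The compounds shown leave open at what concentration any of them becomes cytotoxic, and whether the changed groups differ at all: the limit of > 100000 nM in this assay, at which 4 of the 4 values shown sit.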